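The source may report more compounds than this note shows. Statements on the series, on what has been measured and on what is new or still open speak of the compounds shown alone.

Working notes on the series. Compound 1 `COc1ccc(-n2c(SCc3ccccc3)nnc2-c2cc(OC)c(OC)c(OC)c2)cc1` and compound 2 `COc1cc(-c2nnc(SCc3ccccc3)n2-c2ccc(N(C)C)cc2)cc(OC)c1OC` share one core and differ in dimethylamino in place of methoxy on an aromatic carbon. In a functional assay on PC-3 cells (Homo sapiens) for inhibition, read by MTT assay, with a stated time of 48 h (a higher number here means a weaker inhibitor, a lower number a stronger inhibitor), compound 1 gives 34100 nM, and compound 2 gives 55800 nM; the step of a 1.6-fold higher number from compound 1 to compound 2 (0.21 log units; within the scatter) lies within the scatter, so the two numbers are not distinguished. Compound 2 thus stands at one of two numbers that are not told apart.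

Compound 3 `COc1cc(-c2nnc(SCC(=O)c3ccc(F)cc3)n2-c2ccc(N(C)C)cc2)cc(OC)c1OC` keeps the core and substitution of compound 2 and differs only in (4-fluorophenyl)carbonyl in place of phenyl on a saturated chain carbon bound to a sulfur. Among the measured compounds shown here, no measured step touches the benzylsulfanyl side of the core, so no step bears on this change; the single step on record, a 1.6-fold higher number from compound 1 to compound 2 (0.21 log units; within the scatter), concerns a different position and is within the scatter. For compound 3 the number in this assay is therefore estimated as 35000 nM, between 8000 nM and 150000 nM, a step of a 1.6-fold lower number from compound 2 to compound 3 (0.20 log units; within the scatter) that is expected to stay within the scatter.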

Compound 3, half-maximal inhibitory concentration: 42300 nM
Compound 3: middle estimate off by 1.2-fold (0.08 log units), on the low side; the range from low to high includes it.
By their numbers in this assay, from the lowest: compounds 1, 3 and 2 (each within the scatter of the next).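

In this assay, among the compounds shown here, the only measured change on the benzylsulfanyl side of the core, a 1.3-fold lower number from compound 2 to compound 3 (0.12 log units; within the scatter), lies within the scatter, so the two compounds are not told apart. At this place, on a saturated chain carbon bound to a sulfur, (4-fluorophenyl)carbonyl in place of phenyl adds a carbonyl, a fluorine and a hydrogen-bond acceptor with no readable shift in the number, a finding that rests on this one pair, both members carrying dimethylamino. No measurement on hand offers an explanation for this outcome.

On these data alone, whether the same change reads alike with methoxy in place of dimethylamino stays open, as does whether the carbonyl or the fluorine alone would shift the number. Also open, as far as these compounds go, is what an amine, a carboxylic acid or a longer chain at this place would give in this assay.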